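Replacing Hydroxy with Phenyl on an Amide-Type Nitrogen

This account rests on a few compounds, and the source may have more. Where it says the series, first, only, none or still open, it means among the compounds named here.

Of the compounds shown here, three have been tested in a functional assay on HO8910 cells (Homo sapiens) for inhibition, read by MTT assay, with a stated time of 24 h, tested at 10 ug/mL; a higher number here means more inhibition of growth at the concentration tested, a lower number less inhibition of growth. Among the measured compounds shown here, compound 2 (`O=C(CCCCC(S)CCS)NO`) gives 26.2%, the only number in the set. Compound 1 (`O=C(O)CCCCC(CCSC(=O)c1ccccc1)SC(=O)c1ccccc1`) is reported as "not active" (no number reported). Compound 3 (`O=C(CCCCC1CCSS1)Nc1ccc([N+](=O)[O-])c(C(F)(F)F)c1`) is reported as "not active" (no number reported). For the measured compounds named here, neither of these two comes with a number, so compound 2 stands alone on the scale, and no measured step between compounds is available as a guide to the size of a change.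

Compound 4 (`O=C(CCCCC(S)CCS)Nc1ccccc1`) has not yet been measured. It differs from compound 2 by a single change: phenyl in place of hydroxy on an amide-type nitrogen.

In this assay a step somewhat beyond the usual scatter is expected, toward less inhibition of growth, although the evidence for it is thin. This expectation rests on compound 3, which also carries a ring on its amide-type nitrogen and gives "not active" (no number reported). A report without any number therefore remains a real possibility for the new compound. The expected change is a number 12.2 percentage points lower from compound 2 to compound 4 (beyond the scatter). For compound 4 the estimated value is 14%, with an expected range from 0% to 32%.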

Compound 4, percent growth inhibition at one concentration: 5.49%
For compound 4 the middle estimate is 8.5 percentage points above the measured one; measured number inside the range.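

With compound 4, the series gains its first measured step: in this assay, phenyl in place of hydroxy on an amide-type nitrogen gives a number 20.7 percentage points lower from compound 2 to compound 4 (beyond the scatter). This shows that the group on this nitrogen alone can change growth inhibition beyond the usual scatter, with the rest of the structure held constant, which compounds 1 and 3 could not show as they differ from compound 2 in more than one place. Compound 4 still gives a number, 5.49%, so this single change lowers the reading without leaving a "not active" report. The data shown offer no reason for the size of this loss.

From the compounds shown here alone, it remains open whether a methyl or a benzyl group on this nitrogen, or a phenyl ring carrying an amine or a methoxy group, would keep more of the inhibition seen with compound 2 or lose it as well. Also open, going by these compounds, is whether the same exchange would give a step of similar size on the shared core at other concentrations or in other cell lines.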